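The source may hold more compounds than are shown below. What is called first, only, known or untested is meant among the compounds shown, and "the series" means these compounds.

Measured so far in an assay on isolated protein for inhibition of protein kinase C theta type (Homo sapiens), read by TR-FRET, with a stated time of 2 h; a higher number here means a weaker inhibitor, a lower number a stronger inhibitor:
compound 1, `N#Cc1cnc(NCc2cnccc2C(F)(F)F)cc1N[C@H]1CC[C@H](O)CC1`: 350 nM
compound 2, `CO[C@H]1CC[C@@H](CNc2cc(NCc3cnccc3C(F)(F)F)ncc2C#N)CC1`: 70 nM
compound 3, `CNC(=O)[C@H]1CC[C@@H](Nc2cc(NCc3cnccc3C(F)(F)F)ncc2C#N)CC1`: 27 nM

Compound 3 gives the lowest number of the three, beyond the scatter from both others. Compound 4, `CC1(C)[C@@H](Nc2cc(NCc3cnccc3C(F)(F)F)ncc2C#N)C[C@@H]1C(N)=O`, differs from it in one place: 3-carbamoyl-2,2-dimethylcyclobutyl in place of 4-(methylcarbamoyl)cyclohexyl on a nitrogen on an aromatic ring. For the measured compounds named here, two measured steps bear on this position: a 13-fold lower number from compound 1 to compound 3 (1.11 log units; beyond the scatter) and a 2.6-fold lower number from compound 2 to compound 3 (0.41 log units; beyond the scatter), both moving toward compound 3. Neither covers a four-membered ring or a primary amide, so the direction here is open; a change in this assay beyond the scatter is plausible either way, with some loss somewhat more likely than a further gain, as compound 3 already gives 27 nM, the lowest here. Compound 4 is therefore estimated at 60 nM, range 20 nM to 200 nM. This estimate means an expected step of a 2.2-fold higher number from compound 3 to compound 4 (0.35 log units; beyond the scatter).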

Compound 4, half-maximal inhibitory concentration: 1100 nM
Estimate against measurement, compound 4: 18-fold (1.26 log units) below; measured number above the stated range.
By their numbers in this assay, from the lowest: compound 3; then compound 2; then compound 1; then compound 4.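

At this place, on a nitrogen on an aromatic ring, 3-carbamoyl-2,2-dimethylcyclobutyl is the only group shown that falls behind 4-hydroxycyclohexyl in this assay, with a 3.1-fold higher number from compound 1 to compound 4 (0.50 log units; beyond the scatter) in that comparison. The carbonyl-bearing side chain therefore does not by itself keep the number low: the series shows a 41-fold higher number from compound 3 to compound 4 (1.61 log units; beyond the scatter) for the swap from 4-(methylcarbamoyl)cyclohexyl and a 16-fold higher number from compound 2 to compound 4 (1.20 log units; beyond the scatter) for the swap from (4-methoxycyclohexyl)methyl. Nothing measured here gives a reason for this loss.

The four-membered ring, its two methyl groups and the primary amide remain unseparated. A cyclohexyl carrying a primary amide, or the cyclobutyl without the two methyl groups, would pull these apart.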